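Chloro in place of methoxy: working notes

This account rests on a few compounds, and the source may have more. Where it says the series, first, only, none or still open, it means among the compounds named here.

Values in a functional assay on NCI-H460 cells (Homo sapiens) for cytotoxicity, read by MTT assay, with a stated time of 72 h; on this read-out higher numbers stand for weaker inhibition and lower numbers for stronger inhibition
- compound 1 `CC(=O)c1ccc(/N=C2\C=C(OCc3cn(S(=O)(=O)c4ccc(C)cc4)nn3)C(=O)c3ccccc32)cc1` gives 15800 nM
- compound 2 `COc1ccc(/N=C2\C=C(OCc3cn(S(=O)(=O)c4ccc(C)cc4)nn3)C(=O)c3ccccc32)cc1` gives 8390 nM

Not yet measured
- compound 3 `Cc1ccc(S(=O)(=O)n2cc(COC3=C/C(=N\c4ccc(Cl)cc4)c4ccccc4C3=O)nn2)cc1`

Compound 2 stands within the scatter of compound 1, so these two values set no order. Compound 3 has chloro in place of methoxy on an aromatic carbon, para to a large group (chloro in place of methoxy on an aromatic carbon). Among the compounds with values here, one measured step bears on this place (a 1.9-fold lower number from compound 1 to compound 2 (0.27 log units; within the scatter)). It is methoxy in place of acetyl on an aromatic carbon, and it lies within the scatter. Within the data shown here, that single step is thin evidence, and no measured compound carries chloro. In this assay no step beyond the scatter is therefore expected, and no direction is favoured. The estimated move is small (a 1.2-fold higher number from compound 2 to compound 3 (0.08 log units; within the scatter)). Compound 3 is estimated at 10000 nM (expected range 4000 nM to 25000 nM).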

Compound 3, half-maximal inhibitory concentration: 12100 nM
Compound 3: the middle estimate sits 1.2-fold (0.08 log units) below what was measured, within the range that was stated.
By their numbers in this assay, from the lowest: compounds 2, 3 and 1 (each within the scatter of the next).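

In this assay, chloro at this place on the aromatic ring, para to a large group, gives no step beyond the scatter from either earlier group: a 1.4-fold higher number from compound 2 to compound 3 (0.16 log units; within the scatter) and a 1.3-fold lower number from compound 1 to compound 3 (0.12 log units; within the scatter). Acetyl, methoxy and chloro therefore form a set of three that this read-out does not separate at this position, where the earlier pair offered only a single comparison. Nothing measured on these compounds offers an explanation for this result.

On these data alone, whether an amine, a carboxylic acid or a longer alkoxy chain at this same place would give a step beyond the scatter remains open. Also open, as far as these compounds go, is whether a change elsewhere on the shared core would move the number further than any change at this place has so far in this assay.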